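A few compounds are considered here, and "the series" means these few. Any claim that something is new, unique, unknown or untested is made for them only; others in the source may bear on it.

Values in a functional assay on THP-1 cells (Homo sapiens) for inhibition, read by sulforhodamine B assay, with a stated time of 48 h; on this read-out higher numbers stand for weaker inhibition and lower numbers for stronger inhibition:

- compound 1 `COC(=O)[C@H]1C[C@@H](c2coc3ccccc3c2=O)N(c2ccccc2)O1`: > 60000 nM
- compound 2 `O=c1c([C@@H]2C[C@H](c3ccccc3)ON2c2ccccc2)coc2cc(Cl)c(Cl)cc12`: 38000 nM
- compound 3 `O=C1[C@H]2[C@H](ON(c3ccccc3)[C@@H]2c2coc3ccc(F)cc3c2=O)C(=O)N1c1ccccc1`: 43500 nM

Compound 1 gives no number, only a limit of the assay: > 60000 nM. Its standing is therefore open-ended, and (the limit of > 60000 nM in this assay, at which 1 of the 3 values shown sits). Compound 2 and compound 3 both give numbers, and these lie within the usual scatter of each other.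

The next compound to be measured is compound 4 `O=c1c([C@@H]2C[C@H](c3ccccc3)ON2c2ccccc2)coc2ccccc12`, which has phenyl in place of methoxycarbonyl on a saturated ring carbon. Among the measured compounds shown here, no measured pair isolates this change, so the size of the step in this assay is uncertain. Compound 2 also carries phenyl at that ring carbon and gives 38000 nM, which points to a modest move towards stronger inhibition. The expected change is an at least 1.3-fold lower number from compound 1 to compound 4 (0.12 log units; that floor lies within the scatter), and a second reading at the limit would not be a surprise. For compound 4 the estimated value is 45000 nM, with an expected range from 20000 nM to 80000 nM.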

Compound 4, half-maximal inhibitory concentration: > 60000 nM
Compound 4: a limit, no number; the forecaster's own chance of this, stated with the estimate: 35%; at least 1.3-fold (0.12 log units) between middle value and limit.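

Among the compounds shown here, compound 1 and compound 4 both stand only as limits, not numbers, in this assay, so no step between them can be read: the limit of > 60000 nM in this assay, at which 2 of the 4 values shown sit.

The compounds shown leave open what size of step, if any, phenyl in place of methoxycarbonyl on a saturated ring carbon produces.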